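The source may hold more compounds than are shown below. What is called first, only, known or untested is meant among the compounds shown, and "the series" means these compounds.

Compound 1 `CNC(=O)c1ccc(Oc2cccc(NC(=S)Nc3ccc(Cl)cc3)c2)nc1`: 42500 nM
Compound 2 `CNC(=O)c1ccc(Oc2cccc(NC(=S)Nc3cccc(C(F)(F)F)c3)c2)nc1`: 36700 nM
Compound 3 `CNC(=O)c1ccc(Oc2cccc(NC(=S)Nc3ccc(Cl)cc3Cl)c2)nc1`: 20900 nM

Three thiourea compounds sharing one core were tested in a functional assay on HCT-116 cells (Homo sapiens) for antiproliferative activity, read by MTT assay; a higher number here means a weaker inhibitor, a lower number a stronger inhibitor. In this assay compound 1 gives 42500 nM, compound 2 gives 36700 nM and compound 3 gives 20900 nM. Compound 2 differs from compound 1 by 3-(trifluoromethyl)phenyl in place of 4-chlorophenyl on an amide-type nitrogen, and this gave a 1.2-fold lower number from compound 1 to compound 2 (0.06 log units; within the scatter). Compound 3 differs from compound 1 by chloro in place of hydrogen on an aromatic carbon, which gave a 2.0-fold lower number from compound 1 to compound 3 (0.31 log units; beyond the scatter). Compound 4 `CNC(=O)c1ccc(Oc2cccc(NC(=S)Nc3ccc(Cl)c(C(F)(F)F)c3)c2)nc1` has not been measured; it differs from compound 2 by chloro in place of hydrogen on an aromatic carbon. This is the same kind of change as that from compound 1 to compound 3, but not the same: in compound 4 the chloro enters ortho to a trifluoromethyl group and para to a large group, whereas in compound 3 it enters ortho to a large group and meta to a chloro group. The step of a 2.0-fold lower number from compound 1 to compound 3 (0.31 log units; beyond the scatter) is modest, so compound 4 is expected to show a step of similar size, a 1.7-fold lower number from compound 2 to compound 4 (0.22 log units; within the scatter), from compound 2, resting only on that single earlier pair. Compound 4 is estimated at 22000 nM, likely between 9000 nM and 50000 nM.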

Compound 4, half-maximal inhibitory concentration: 2210 nM
Compound 4: the middle estimate sits 10-fold (1.00 log units) above what was measured, and the stated range ends above it.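

In this assay, the chloro step did not carry over at the same size from one core to the other: the same change on two cores in this assay, a 2.0-fold lower number (0.31 log units; beyond the scatter) from compound 1 to compound 3 and a 17-fold lower number (1.22 log units; beyond the scatter) from compound 2 to compound 4, 8.2-fold (0.91 log units) apart, beyond the scatter of two such steps. On the core of compound 2, chloro gave a 17-fold lower number from compound 2 to compound 4 (1.22 log units; beyond the scatter), and on the core of compound 1, trifluoromethyl gave a 19-fold lower number from compound 1 to compound 4 (1.28 log units; beyond the scatter), so the pairing of the two groups in compound 4 gave far more than either single step into compound 3 or compound 2 would suggest. This shows that the size of the chloro step cannot be transferred between these cores, but with one pair on each core it does not show why, nor can it separate the change of core from the placing of the chloro, which in compound 4 is ortho to a trifluoromethyl group and para to a large group.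

As far as these compounds go, it remains open whether a bromo or a methyl group in place of that chloro would give a similar step. From the compounds shown here alone, it is also open whether a nitrile in place of the trifluoromethyl would keep the level of compound 4.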